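The source may report more compounds than this note shows. Statements on the series, on what has been measured and on what is new or still open speak of the compounds shown alone.

The measured compounds, each with its result in a growth assay on colon cancer cells:

- Compound 1 `O=S(=O)(NCCCNCc1ccc(C(F)(F)F)cc1)c1cc(C(F)(F)F)cc(C(F)(F)F)c1` gives 2900 nM in a functional assay on HT-29 cells (Homo sapiens) for inhibition, read by MTT assay, with a stated time of 72 h; a higher number here means a weaker inhibitor of growth, a lower number a stronger inhibitor of growth.
- Compound 2 `O=S(=O)(NCCCNCc1ccc(Br)cc1)c1cc(C(F)(F)F)cc(C(F)(F)F)c1` gives 2200 nM in this assay.
- Compound 3 `O=S(=O)(NCCCNCc1ccc(-c2ccccc2)cc1)c1cc(C(F)(F)F)cc(C(F)(F)F)c1` gives 2300 nM in this assay.

All three share the same core and differ only in one group on the outer aromatic ring. Compound 3 holds the second highest of the three numbers, but the spread is small: the step of a 1.0-fold higher number from compound 2 to compound 3 (0.02 log units; within the scatter) and the step of a 1.3-fold lower number from compound 1 to compound 3 (0.10 log units; within the scatter) both fall inside the scatter, so no ordering among the three can be read from these values.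

Compound 4 `O=S(=O)(NCCCNCc1ccc(Cl)cc1)c1cc(C(F)(F)F)cc(C(F)(F)F)c1` carries the change (chloro in place of phenyl on an aromatic carbon). Going by the values given here, the steps that bear on it are the swaps already tried at the same position: a 1.3-fold lower number from compound 1 to compound 2 (0.12 log units; within the scatter), a 1.3-fold lower number from compound 1 to compound 3 (0.10 log units; within the scatter) and a 1.0-fold higher number from compound 2 to compound 3 (0.02 log units; within the scatter). Each of these exchanged one group for another at that carbon, and none moved the number beyond the scatter. Chloro has not yet been tested there, and chloro is a halogen like the bromo of compound 2, which gave 2200 nM.

On that basis the step of a 1.0-fold higher number from compound 3 to compound 4 (0.02 log units; within the scatter) is expected to stay within the scatter, in no clear direction. Compound 4 is therefore estimated to give 2400 nM in this assay, with a plausible range from 1200 nM to 5000 nM.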

Compound 4, concentration for 50% growth inhibition: 2800 nM
Compound 4: middle estimate off by 1.2-fold (0.07 log units), on the low side, within the range that was stated.
By their numbers in this assay, from the lowest: compounds 2, 3, 4 and 1 (each within the scatter of the next).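

Going by these compounds alone, removing the phenyl's six heavy atoms and putting a single chlorine on this aromatic carbon still gives only the step of a 1.2-fold higher number from compound 3 to compound 4 (0.09 log units; within the scatter) in this assay, so a group as small as chloro and one as large as phenyl cannot be told apart here. The two halogens cannot be told apart either, with the step of a 1.3-fold higher number from compound 2 to compound 4 (0.10 log units; within the scatter) also inside the scatter, and the same holds for chloro and trifluoromethyl, with the step of a 1.0-fold lower number from compound 1 to compound 4 (0.02 log units; within the scatter) completing the set of comparisons for the four groups at this carbon. Nothing available explains why these exchanges give such close numbers.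

Still open is whether a group of a different kind on this carbon, such as an amine or a carboxylic acid, would give a step beyond the scatter, since the four groups shown are only trifluoromethyl, bromo, phenyl and chloro. Also open, going by these compounds, is whether a change elsewhere in the shared core, such as a longer chain in place of the present one, would matter more than any exchange at this carbon.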